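A few compounds are considered here, and "the series" means these few. Any claim that something is new, unique, unknown or untested is made for them only; others in the source may bear on it.

Measured compounds:
Compound 1, `CCC(C)(C)Cc1c[nH]c(CCc2ccc(-c3cccc(C)n3)cc2)n1`, gives 106 nM in a functional assay on HEK293 cells for agonist activity at Bombesin receptor subtype-3 (Mus musculus), read by luminescence and calcium flux, with a stated time of 10 min; a higher number here means that more compound is needed for the effect, a lower number that less compound is needed.
Compound 2, `CCC(C)(C)Cc1c[nH]c(CCc2ccc(-c3cccc(N)n3)cc2)n1`, gives 119 nM in this assay.

On these two numbers compound 1 stands lowest, but its nearest neighbour is compound 2, and the step of a 1.1-fold higher number from compound 1 to compound 2 (0.05 log units; within the scatter) lies within the scatter, so no order between them can be claimed. Compound 3, `CCC(C)(C)Cc1c[nH]c(CCc2ccc(-c3csnn3)cc2)n1`, has not yet been measured in this assay. It differs from compound 1 as follows: 1,2,3-thiadiazol-4-yl in place of 6-methylpyridin-2-yl on an aromatic carbon. For the measured compounds named here, the only measured step in this part of the molecule, a 1.1-fold higher number from compound 1 to compound 2 (0.05 log units; within the scatter), concerns a small exchange on the 6-methylpyridin-2-yl group and stayed within the scatter; the exchange leading to compound 3 removes that group entirely, and nothing measured bears directly on it. Compound 3 is therefore expected to need somewhat more compound, an estimated step of a 2.8-fold higher number from compound 1 to compound 3 (0.45 log units; beyond the scatter), with wide uncertainty. The estimate for compound 3 is 300 nM, ranging from 80 nM to 1500 nM.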

Compound 3, half-maximal effective concentration: 109 nM
For compound 3 the middle estimate is 2.8-fold (0.44 log units) above the measured one; the measured number falls inside the stated range.
By their numbers in this assay, from the lowest: compounds 1, 3 and 2 (each within the scatter of the next).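

In this assay, the exchange of the whole 6-methylpyridin-2-yl group for 1,2,3-thiadiazol-4-yl, on an aromatic carbon para to a large group, gives a 1.0-fold higher number from compound 1 to compound 3 (0.01 log units; within the scatter), and the exchange from 6-aminopyridin-2-yl gives a 1.1-fold lower number from compound 2 to compound 3 (0.04 log units; within the scatter). The earlier pair covered only a small exchange on the six-membered ring, whereas these steps show that a five-membered aromatic ring with 3 hetero atoms and fewer heavy atoms can stand at this place with no difference that can be read. No supporting evidence accounts for this result. The compounds shown leave open whether this holds for a group without an aromatic ring at this carbon, such as a carboxylic acid, an amine or a longer chain.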